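A Methylimidazole Replaces the Oxazole Arm

This account rests on a few compounds, and the source may have more. Where it says the series, first, only, none or still open, it means among the compounds named here.

Compound 1 `N#Cc1ccc(-c2cc(-c3ccc(C(N)=O)cc3)cc(-c3cncs3)n2)cc1` carries a thiazole ring on the shared core, and in an assay on cells for binding affinity to Myc proto-oncogene protein (Homo sapiens) (a higher number here means a weaker inhibitor, a lower number a stronger inhibitor), compound 1 gives 30000 nM. Compound 2 `N#Cc1ccc(-c2cc(-c3ccc(C(N)=O)cc3)cc(-c3cnco3)n2)cc1` differs only in that five-membered ring, where an oxazole stands in place of the thiazole. In this assay compound 2 reaches only the limit of the assay, > 100000 nM, so no exact number is known for it. The step of an at least 3.3-fold higher number from compound 1 to compound 2 (0.52 log units; beyond the scatter) is therefore a weakening whose full size is hidden by the limit of > 100000 nM in this assay, at which 1 of the 2 values shown sits. Compound 3 `Cn1ccnc1-c1cc(-c2ccc(C(N)=O)cc2)cc(-c2ccc(C#N)cc2)n1` changes the same ring once more: 1-methyl-1H-imidazol-2-yl in place of 1,3-oxazol-5-yl on an aromatic carbon. Among the measured compounds shown here, no measured pair shows this exact exchange; the one step that bears on it, from thiazole to oxazole, shows that small changes in this five-membered ring move the number beyond the scatter. For compound 3 a weak binder is expected, with an estimate of 60000 nM in a range from 20000 nM to 200000 nM. That estimate for compound 3 implies an at least 1.6-fold lower number from compound 2 to compound 3 (0.22 log units; that floor lies within the scatter), though a further limit reading is possible.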

Compound 3, half-maximal inhibitory concentration in the Myc proto-oncogene protein assay: 40000 nM
Compound 3: the middle estimate sits 1.5-fold (0.18 log units) above what was measured; measured number inside the range.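

In the Myc proto-oncogene protein assay, the 1-methyl-1H-imidazol-2-yl group gives measurable binding at this position, with an at least 2.5-fold lower number from compound 2 to compound 3 (0.39 log units; beyond the scatter), so the loss seen with the 1,3-oxazol-5-yl group does not extend to every five-membered ring here. In the Myc proto-oncogene protein assay, the comparison with the thiazole gives a 1.3-fold higher number from compound 1 to compound 3 (0.12 log units; within the scatter), so compound 1 and compound 3 cannot be told apart, and both remain weak binders. In a physicochemical assay for solubility, at pH 6 (on this read-out lower numbers stand for lower solubility and higher numbers for higher solubility), compound 2 gives 250000 nM, and compound 3 gives 8000 nM. The exchange that recovers binding comes with a clear drop in the physicochemical assay: the measured solubility of compound 2, 250000 nM, and of compound 3, 8000 nM, a 31-fold lower number (1.49 log units; beyond the scatter)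

As far as these compounds go, the full size of the step from compound 2 stays open, since the value of compound 2 is only a limit of the assay: the limit of > 100000 nM in the Myc proto-oncogene protein assay, at which 1 of the 3 values shown sits. Also open is whether a morpholine or another amine on this carbon of the shared core would bind more strongly without that loss of solubility.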